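Changing the Group on the Sulfonyl Sulfur

A few compounds are considered here, and "the series" means these few. Any claim that something is new, unique, unknown or untested is made for them only; others in the source may bear on it.

Measured so far:
compound 1 `CN1CCC(S(=O)(=O)c2ccc3nc(NC(=O)NC(=O)c4cc(N5CCCC5)ccc4Cl)sc3c2)CC1` gives 0.92 nM in an assay on HEK293 cells for displacement of a labelled ligand from growth hormone secretagogue receptor type 1 (Homo sapiens), with a stated time of 60 min; on this read-out higher numbers stand for weaker inhibition and lower numbers for stronger inhibition
compound 2 `CN1CCC(S(=O)(=O)c2ccc3nc(NC(=O)NC(=O)c4cc(-n5cccn5)ccc4Cl)sc3c2)CC1` gives 15 nM
compound 3 `CN1CCC(S(=O)(=O)c2ccc3nc(NC(=O)NC(=O)c4cc(N5CCCC5)c(C#N)cc4Cl)sc3c2)CC1` gives 0.4 nM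

Among these three numbers compound 1 stands second highest: compound 3 sits below it, a 2.3-fold lower number from compound 1 to compound 3 (0.36 log units; beyond the scatter), while compound 2 sits well above it, a 16-fold higher number from compound 1 to compound 2 (1.21 log units; beyond the scatter). Both of these measured steps swap a group on an aromatic carbon, and neither touches the sulfonyl sulfur. Compound 4 `CN1CCN(CCCS(=O)(=O)c2ccc3nc(NC(=O)NC(=O)c4cc(N5CCCC5)ccc4Cl)sc3c2)CC1` differs from compound 1 only there: 3-(4-methylpiperazin-1-yl)propyl in place of 1-methylpiperidin-4-yl on a sulfonyl sulfur. Going by the values given here, no measured step bears on this kind of change, so there is no direct guide to its size; the expected outcome is therefore a step of at most modest size, a 1.6-fold higher number from compound 1 to compound 4 (0.21 log units; within the scatter). On that basis compound 4 is estimated at 1.5 nM, with a range from 0.5 nM to 5 nM.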

Compound 4, half-maximal inhibitory concentration: 0.29 nM
Compound 4: middle estimate off by 5.2-fold (0.71 log units), on the high side; the whole stated range lies above it.
By their numbers in this assay, from the lowest: compounds 4 and 3 (each within the scatter of the next); then compound 1; then compound 2.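

Going by these compounds alone, the sulfonyl sulfur, untouched by the earlier steps, can carry a longer group without losing inhibition: in this assay, replacing 1-methylpiperidin-4-yl with 3-(4-methylpiperazin-1-yl)propyl gives a 3.2-fold lower number from compound 1 to compound 4 (0.50 log units; beyond the scatter) and adds a second ring nitrogen. No measurement shown explains this gain.

The change alters both the ring and its link to the sulfur, so the compounds shown cannot separate the two effects. As far as these compounds go, it remains open whether a 2-(4-methylpiperazin-1-yl)ethyl chain or an open-chain amine such as 3-(dimethylamino)propyl would do as well.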